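The compounds below may be only part of what the source reports. "The series", "measured", "known", "first", "only" and "open" are said of these compounds alone.

Measured compounds:
Compound 1, `Nc1ccc(C(=O)/C=C/c2ccc(O)c(F)c2)cc1-c1ccc(F)cc1` — 24500 nM
Compound 2, `COc1ccc(/C=C/C(=O)c2ccc(N)c(-c3ccc(F)cc3)c2)cc1OC` — 8630 nM

In a functional assay on A549 cells (Homo sapiens) for cytotoxicity, read by sulforhodamine B assay, with a stated time of 48 h (on this read-out lower numbers stand for stronger inhibition and higher numbers for weaker inhibition), compound 2 gives the lowest of the two numbers; compound 1, at 24500 nM, stands beyond the scatter above it. Compound 3, `COc1ccc(/C=C/C(=O)c2ccc(N)c(-c3ccc(F)cc3)c2)cc1`, has not been measured. It differs from compound 2 by hydrogen in place of methoxy on an aromatic carbon. Among the compounds with values here, no step between two measured compounds bears on this change, so the account rests on compound 2 alone. A small step in this assay is expected, if any, toward a weaker value, since the methoxy group is simply taken away. Compound 3 is estimated at 12000 nM, between 5000 nM and 30000 nM, the expected step being a 1.4-fold higher number from compound 2 to compound 3 (0.14 log units; within the scatter).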

Compound 3, half-maximal inhibitory concentration: 4310 nM
Compound 3: middle estimate off by 2.8-fold (0.44 log units), on the high side; measured number outside the range, below it.
By their numbers in this assay, from the lowest: compounds 3 and 2 (each within the scatter of the next); then compound 1.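

In this assay, within the data shown here, hydrogen in place of methoxy on this aromatic carbon, ortho to a methoxy group, gives a 2.0-fold lower number from compound 2 to compound 3 (0.30 log units; within the scatter), so removing this group does not move the number beyond the scatter. 4-Methoxyphenyl in place of 3-fluoro-4-hydroxyphenyl gives a 5.7-fold lower number from compound 1 to compound 3 (0.75 log units; beyond the scatter), the only step so far that lies beyond the scatter. Nothing given here explains either step. Which part of the 3-fluoro-4-hydroxyphenyl group accounts for the larger step stays open. So does the effect of an amine, a chlorine atom or a longer alkoxy chain on this aromatic carbon.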